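Allyl to propyl: working notes on the series

The source may report more compounds than this note shows. Statements on the series, on what has been measured and on what is new or still open speak of the compounds shown alone.

In a functional assay on HL-60 cells (Homo sapiens) for antiproliferative activity, read by MTT assay (on this read-out higher numbers stand for weaker inhibition and lower numbers for stronger inhibition), compound 1 (`O[C@@H]1[C@@H](OCc2ccccc2)[C@H](OCc2ccccc2)[C@@H](COCc2ccccc2)O[C@@H]1CC1CCCCC1`) gives 17200 nM and compound 2 (`c1ccc(COC[C@H]2OCC[C@@H](OCc3ccccc3)[C@@H]2OCc2ccccc2)cc1`) gives 39300 nM as its value. Compound 3 (`C=CC[C@@H]1O[C@H](COCc2ccccc2)[C@@H](OCc2ccccc2)[C@H](OCc2ccccc2)[C@@H]1O`) has no single number, and its entry in this assay reads "not active" (no number reported) without a value to place beside the other two. The next structure is compound 4 (`CCC[C@@H]1O[C@H](COCc2ccccc2)[C@@H](OCc2ccccc2)[C@H](OCc2ccccc2)[C@@H]1O`), and the change is ethyl in place of vinyl on a saturated chain carbon bound to a saturated ring carbon (ethyl in place of vinyl on a saturated chain carbon bound to a saturated ring carbon, or allyl to propyl when cut one bond further out). For the measured compounds named here, no measured pair isolates this change, so its effect remains open. In this assay no step beyond the scatter is expected in either direction, so compound 4 should remain weak and may also return no number. The nearest numeric guide is compound 2 at 39300 nM in this series. If a number is reported, compound 4 is estimated at 30000 nM (12000 nM to 80000 nM).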

Compound 4, half-maximal inhibitory concentration: "not active" (no number reported)
Nothing numeric was reported for compound 4; there is nothing to compare the estimate with.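

In this assay compound 3 and compound 4 are both reported as "not active" without a number, so no step can be read for allyl to propyl. No supporting evidence bears on this result. The compounds shown leave open whether this change has any effect on activity.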